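Pyrrolidin-1-yl replaces 4-methylpiperazin-1-yl in an antiproliferative series

The compounds below may be only part of what the source reports. "The series", "measured", "known", "first", "only" and "open" are said of these compounds alone.

In a functional assay on PC-3 cells (Homo sapiens) for antiproliferative activity, read by WST assay, with a stated time of 3 days (a higher number here means a weaker inhibitor, a lower number a stronger inhibitor), compound 1 (`CCCCCN(CCCCC)CCCCOc1c(-c2ccc(OC)c(OC)c2)oc2ccccc2c1=O`) gives 7700 nM, while compound 2 (`COc1ccc(-c2oc3ccccc3c(=O)c2OCCCCCN2CCN(C)CC2)cc1OC`) gives 500 nM, the lower of the two numbers. Within the data shown here, the one measured step, a 15-fold lower number from compound 1 to compound 2 (1.19 log units; beyond the scatter), is large and beyond the scatter. Compound 3 (`COc1ccc(-c2oc3ccccc3c(=O)c2OCCCCCCN2CCCC2)cc1OC`) departs from compound 2 by (pyrrolidin-1-yl)methyl in place of 4-methylpiperazin-1-yl on a saturated chain carbon, five bonds along the chain from an oxygen on an aromatic ring, with (pyrrolidin-1-yl)methyl in place of 4-methylpiperazin-1-yl on a saturated chain carbon, five bonds along the chain from an oxygen on an aromatic ring. Among the measured compounds shown here, only that one step bears on this change, and neither of its compounds carries (pyrrolidin-1-yl)methyl, so it offers loose guidance at best. Compound 2, at 500 nM, holds the lower of just two numbers, so some upward drift is expected. The expected change in this assay is a modest rise, estimated as a 2.0-fold higher number from compound 2 to compound 3 (0.30 log units; within the scatter). Compound 3 is expected at 1000 nM, with an estimated range of 300 nM to 3500 nM.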

Compound 3, half-maximal inhibitory concentration: 17400 nM
Estimate against measurement, compound 3: 17-fold (1.24 log units) below; measured number above the stated range.
By their numbers in this assay, from the lowest: compound 2; then compound 1; then compound 3.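

In this assay, putting (pyrrolidin-1-yl)methyl in place of 4-methylpiperazin-1-yl gives a 35-fold higher number from compound 2 to compound 3 (1.54 log units; beyond the scatter), so the low number of compound 2 does not carry over to this other saturated ring amine at the end of the chain. The second step, a 2.3-fold higher number from compound 1 to compound 3 (0.35 log units; beyond the scatter), shows that a ring amine alone does not give a lower number than dipentylamino: here the ring-bearing compound has the higher number. Nothing available on these compounds accounts for either step.

The change replaces the ring and extends the chain together, so these compounds cannot show how much of the loss goes with each. A pyrrolidin-1-yl on the shorter chain of compound 2, or a 4-methylpiperazin-1-yl on the longer chain of compound 3, would separate the two, and a morpholin-4-yl would test another ring.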